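Swapping a methyl for a nitrile on a receptor antagonist core

The source may hold more compounds than are shown below. What is called first, only, known or untested is meant among the compounds shown, and "the series" means these compounds.

Compound 1 `COCc1cc(OC)c(-c2cccc3c(N(CC4CCOCC4)CC4CC4)c(C)nn23)c(OC)c1`: 50 nM
Compound 2 `CCc1nn2c(-c3ccc(OC)cc3Cl)cccc2c1N(CC1CC1)CC1CC1`: 100 nM

Of the compounds shown here, two have been measured in a functional assay on HEK293 cells for antagonist activity at corticotropin-releasing factor receptor 1 (Homo sapiens), read by fluorescence and cAMP accumulation, with a stated time of 30 min; a higher number here means a weaker inhibitor, a lower number a stronger inhibitor. Compound 1 gives 50 nM, and compound 2 gives 100 nM; the two numbers sit within the usual scatter of each other, so neither can be called the stronger inhibitor.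

Compound 3 `COCc1cc(OC)c(-c2cccc3c(N(CC4CCOCC4)CC4CC4)c(C#N)nn23)c(OC)c1` has not yet been measured. It differs from compound 1 in one place: cyano in place of methyl on an aromatic carbon. Within the data shown here, no measured pair shows this change, so no step can be read off. A small change is expected, probably none beyond the scatter, with the step from compound 1 to compound 3 estimated at a 1.6-fold higher number from compound 1 to compound 3 (0.20 log units; within the scatter). Compound 3 is expected to give about 80 nM, within a range of 25 nM to 250 nM.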

Compound 3, half-maximal inhibitory concentration: 52 nM
Estimate against measurement, compound 3: 1.5-fold (0.19 log units) above, within the range that was stated.
By their numbers in this assay, from the lowest: compounds 1, 3 and 2 (each within the scatter of the next).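

In this assay, putting cyano in place of methyl on this aromatic carbon gives a 1.0-fold higher number from compound 1 to compound 3 (0.02 log units; within the scatter). The earlier compounds shown here could not show this: at this position, next to the ring nitrogen, methyl can give way to a group with a triple bond and a hydrogen-bond acceptor without a change that stands out from the scatter. No measurement here explains why the two groups give such similar numbers.

On these data alone, whether an amine or a carboxylic acid on this carbon would also stay within the scatter remains open. So does whether cyano would behave the same way on a different core.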